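A few compounds are considered here, and "the series" means these few. Any claim that something is new, unique, unknown or untested is made for them only; others in the source may bear on it.

Values in a functional assay on KM12 cells (Homo sapiens) for inhibition, read by sulforhodamine B assay, with a stated time of 48 h; on this read-out lower numbers stand for stronger inhibition of growth and higher numbers for weaker inhibition of growth
compound 1 `CCCCCCCCCCCC[C@@H](O)[C@H]1CC[C@H]([C@H](O)CCCCCCCCCCNC(=O)c2ccnn2C)O1` gives 100000 nM
compound 2 `CCCCCCCCCCCC[C@@H](O)[C@H]1CC[C@H]([C@H](O)CCCCCCCCCCN(C)C(=O)c2ccnn2C)O1` gives 4170 nM
compound 3 `CCCCCCCCCCCC[C@@H](O)[C@H]1CC[C@H]([C@H](O)CCCCCCCCCCC(=O)Nc2ccnn2C)O1` gives 100000 nM

Compound 3 stands level with compound 1 at the digits shown, and together they hold the highest of the three numbers. Compound 4 `CCCCCCCCCCCC[C@@H](O)[C@H]1CC[C@H]([C@H](O)CCCCCCCCCCOC(=O)c2ccnn2C)O1` differs from compound 3 by ((1-methyl-1H-pyrazol-5-yl)carbonyl)oxy in place of (1-methyl-1H-pyrazol-5-yl)carbamoyl on a saturated chain carbon, ten or more bonds along the chain from an oxygen on a saturated carbon and a saturated ring carbon and nothing else. Going by the values given here, two measured steps bear on this. Reversing the amide gave no change at the digits printed from compound 1 to compound 3 (within the scatter) in this series, while methyl in place of hydrogen on the amide-type nitrogen gave a 24-fold lower number from compound 1 to compound 2 (1.38 log units; beyond the scatter) as the one large step. Among the compounds with values here, compound 4, like compound 2, has no amide hydrogen, so part of that large step is expected to carry over, although no measured step places oxygen in this linkage. The expected step is an 8.3-fold lower number from compound 3 to compound 4 (0.92 log units; beyond the scatter) towards a lower number. The estimate for compound 4 is 12000 nM within a range of 2500 nM to 100000 nM for this read-out.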

Compound 4, concentration for 50% growth inhibition: 20000 nM
Compound 4: middle estimate off by 1.7-fold (0.22 log units), on the low side; the measured number falls inside the stated range.
By their numbers in this assay, from the lowest: compound 2; then compound 4; then compounds 1 and 3 (each within the scatter of the next).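

In this assay, the ester linkage gives a 5.0-fold lower number from compound 3 to compound 4 (0.70 log units; beyond the scatter) and a 5.0-fold lower number from compound 1 to compound 4 (0.70 log units; beyond the scatter), so this chain position responds to a linkage change even though reversing the amide moved nothing at the digits printed. The amide hydrogen is also absent from compound 4, yet the methylated amide remains separated by a 4.8-fold higher number from compound 2 to compound 4 (0.68 log units; beyond the scatter), so lacking that hydrogen does not alone set the number. No measured evidence bears on the origin of these steps.

Open, as far as these compounds go, is whether an ether linkage or an N-ethyl amide in this place would read nearer compound 2 or compound 4. Also open, from the compounds shown here alone, is whether these steps persist with a longer chain.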